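Moving the bromine on the aryl group of compound 1

The source may report more compounds than this note shows. Statements on the series, on what has been measured and on what is new or still open speak of the compounds shown alone.

For the measured compounds named here, compound 1 `O=C(O)CCCC/C=C(\c1cccnc1)c1cccc(Br)c1` is one of three compounds measured in an assay (Equus caballus) for inhibition of Thromboxane-A synthase (Homo sapiens), using microsomes; on this read-out higher numbers stand for weaker inhibition and lower numbers for stronger inhibition. Compound 1 gives 180 nM, the second highest of the three numbers. Compound 2 `C/C(=C\CCCCC(=O)O)c1cccnc1` gives 210 nM, which lies within the usual scatter of the number for compound 1. Compound 3 `CC(C)(O)C(CCC/C=C(\c1ccccc1)c1cccnc1)C(=O)O` gives 42 nM, a number beyond the scatter below that of compound 1. Compound 3 differs from compound 1 in more than one place, so its two values can only be set side by side.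

Compound 4 `O=C(O)CCCC/C=C(/c1ccc(Br)cc1)c1cccnc1` has the same atoms as compound 1, joined differently: 4-bromophenyl in place of 3-bromophenyl on a double-bonded chain carbon bound to an aromatic carbon and a double-bonded chain carbon. Going by the values given here, no measured pair follows this change on its own, so any expectation for compound 4 rests on compound 1 alone. Since the bromine stays on the same ring and the rest of the molecule is unchanged, the step of a 1.2-fold lower number from compound 1 to compound 4 (0.08 log units; within the scatter) is expected to be small, with no direction beyond the scatter. Compound 4 is therefore estimated at 150 nM, with a range from 60 nM to 400 nM.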

Compound 4, half-maximal inhibitory concentration: 82 nM
Beside the measured number, compound 4's estimate is 1.8-fold (0.26 log units) above it, within the range that was stated.
By their numbers in this assay, from the lowest: compounds 3 and 4 (each within the scatter of the next); then compounds 1 and 2 (each within the scatter of the next).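

In this assay the place of the bromine on the aryl group proves to matter: 4-bromophenyl in place of 3-bromophenyl leaves the atoms unchanged yet gives a 2.2-fold lower number from compound 1 to compound 4 (0.34 log units; beyond the scatter) and so counts as a modest step beyond the scatter. For the compounds shown here, this is the first pair here that differs in one place, so the position on a double-bonded chain carbon bound to an aromatic carbon and a double-bonded chain carbon can now be read directly rather than only set side by side. Nothing at hand accounts for the direction of this step.

Going by these compounds, it remains open whether a chlorine or a methoxy group in place of the bromine would give a step of similar size and direction. On these data alone, it is also open whether the same change would carry over to the hydroxy-bearing chain of compound 3.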